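The source may hold more compounds than are shown below. What is called first, only, known or untested is meant among the compounds shown, and "the series" means these compounds.

Compound 1, `O=S(=O)(Nc1ccc(-c2nc3ccccc3o2)cc1)c1ccccc1Cl`: > 63000 nM
Compound 2, `COc1cccc(S(=O)(=O)Nc2ccc3oc(-c4ccccc4)nc3c2)c1`: > 63000 nM

Both compounds were tested in an assay on isolated protein for inhibition of malate dehydrogenase, mitochondrial (Sus scrofa), with stated times of 45 min and 30 min; on this read-out higher numbers stand for weaker inhibition and lower numbers for stronger inhibition. Compound 1 gives > 63000 nM, which is a limit of the assay and not a number. Compound 2 gives > 63000 nM, again a limit rather than a number. So compound 1 stands at the limit, and the same holds for every value shown here: the limit of > 63000 nM in this assay, at which 2 of the 2 values shown sit. Neither compound shows inhibition that this assay could put a number on.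

The step to compound 3, `O=S(=O)(Nc1ccc(-c2nc3ccccc3o2)cc1)c1ccccc1O`, changes one place on compound 1: hydroxy in place of chloro on an aromatic carbon. In words, hydroxy takes the place of chloro on an aromatic carbon; the rest of the structure stays as in compound 1. Among the measured compounds shown here, no step between two measured compounds that differ in one place is available, so there is no measured change of similar kind to set a size against. With compound 1 sitting at > 63000 nM, the expectation for compound 3 is a change of no more than the scatter, most likely again a limit, with the step that the limit leaves unreadable from compound 1 to compound 3. Compound 3 is therefore estimated at 80000 nM, between 20000 nM and 300000 nM.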

Compound 3, half-maximal inhibitory concentration: > 63000 nM
Compound 3 ended at the assay's limit (the forecaster's own chance of this, stated with the estimate: 75%); the middle value does not contradict the limit.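

Compound 1 and compound 3 both sit at a limit of this assay and not at a number, so no step from chloro to hydroxy can be read from them, whatever its size: the limit of > 63000 nM in this assay, at which 3 of the 3 values shown sit.

The compounds shown leave open whether any change to these structures gives inhibition that this assay can put a number on.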